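Chloro to Bromo on the Haloketone Chain

The source may hold more compounds than are shown below. What is called first, only, known or untested is meant among the compounds shown, and "the series" means these compounds.

Measured compounds:
compound 1, `Cc1cn(C2CC(O)C(CCC(=O)CCl)O2)c(=O)[nH]c1=O`, 66000 nM
compound 2, `Cc1cn(C2CC(O)C(C(=O)Nc3ccc(C(=O)CCl)cc3)O2)c(=O)[nH]c1=O`, 28000 nM

Of the compounds shown here, two have been measured in a functional assay on L1210 cells (Mus musculus) for inhibition, with a stated time of 48 h; a higher number here means a weaker inhibitor, a lower number a stronger inhibitor. Compound 1 gives 66000 nM, the higher of the two numbers. Compound 2 gives 28000 nM, a lower number than compound 1, and the gap between them lies beyond the usual scatter. Within the data shown here, no single-point step connects compound 1 and compound 2, so the two values are simply set side by side.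

Compound 3, `Cc1cn(C2CC(O)C(CCC(=O)CBr)O2)c(=O)[nH]c1=O`, has not yet been measured. It differs from compound 1 in one place: bromo in place of chloro on a saturated chain carbon bound to a carbonyl carbon. Among the measured compounds shown here, no measured pair shows this exchange. Without such a reference, the expectation for compound 3 rests on compound 1 alone. The expected step from compound 1 to compound 3 in this assay is a small lowering of the number, a 1.7-fold lower number from compound 1 to compound 3 (0.22 log units; within the scatter), which may not exceed the scatter. Compound 3 is therefore estimated at 40000 nM, with a range from 15000 nM to 110000 nM.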

Compound 3, half-maximal inhibitory concentration: 110000 nM
For compound 3 the middle estimate is 2.8-fold (0.44 log units) below the measured one; low and high end bracket the measured number.
By their numbers in this assay, from the lowest: compound 2; then compounds 1 and 3 (each within the scatter of the next).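

In this assay, among these compounds, bromo in place of chloro on a saturated chain carbon bound to a carbonyl carbon provides the first one-place comparison in this set, and it gives a 1.7-fold higher number from compound 1 to compound 3 (0.22 log units; within the scatter). At this position, therefore, the chloromethyl to bromomethyl exchange produces no difference that can be separated from the ordinary spread of repeated measurements, so chloro and bromo cannot be told apart in this assay on the core of compound 1. Nothing is available here that would account for this result.

The compounds shown leave open whether the same exchange would also fall within the scatter on the different chain of compound 2, where only the chloro form appears. They also leave open whether an iodo or fluoro group, or a hydroxyl group, on the same saturated chain carbon would give a number clearly apart from that of compound 1, and whether a longer chain between the core and the carbonyl would change the reading.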